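The source may report more compounds than this note shows. Statements on the series, on what has been measured and on what is new or still open speak of the compounds shown alone.

In a functional assay on 786-0 cells (Homo sapiens) for inhibition, read by sulforhodamine B assay, with a stated time of 48 h (on this read-out lower numbers stand for higher toxicity in this test and higher numbers for lower toxicity in this test), compound 1, `O=C(Nc1cccc(-n2cc(-c3ccncc3)c(-c3ccc(Cl)c(O)c3)n2)c1)Nc1ccc(Cl)c(Cl)c1`, shows no measurable toxicity: its value is a limit of the test, > 32500 nM. Compound 2, `COc1cc(-c2nn(-c3cccc(NC(=O)Nc4ccc(Cl)c(C(F)(F)F)c4)c3)cc2-c2ccncc2)ccc1Cl`, also reaches only a limit in this assay, > 32500 nM. Among the measured compounds shown here, compound 2 therefore stands at the limit of this assay, as does the only other value in view, which the limit of > 32500 nM in this assay, at which 2 of the 2 values shown sit, summarises. The step to compound 3, `O=C(Nc1cccc(-n2cc(-c3ccncc3)c(-c3ccc(Cl)c(O)c3)n2)c1)Nc1ccc(Cl)c(C(F)(F)F)c1`, is hydrogen in place of methyl on an oxygen on an aromatic ring, that is, methoxy to hydroxy on the 4-chloro-3-methoxyphenyl group, giving 4-chloro-3-hydroxyphenyl. For the measured compounds named here, no measured pair in this assay shows what such a change does, so no step beyond the usual scatter is expected in either direction: the expected step from compound 2 to compound 3 is a step that the limit leaves unreadable from compound 2 to compound 3. Since compound 1 carries the same hydroxy group and gives > 32500 nM, compound 3 is likewise expected to sit at the limit, estimated at 50000 nM with a range of 20000 nM to 150000 nM.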

Compound 3, concentration lethal to 50% of the cells: > 32500 nM
Compound 3 ended at the assay's limit (the forecaster's own chance of this, stated with the estimate: 85%); the middle value is on the limit's open side.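

Neither the step from compound 2 to compound 3 nor the step from compound 1 to compound 3 can be read, because all three compounds stand at one limit: the limit of > 32500 nM in this assay, at which 3 of the 3 values shown sit. What the compounds shown leave open is whether either change, methoxy to hydroxy or chloro to trifluoromethyl, alters the result in this assay at all.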